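The compounds below may be only part of what the source reports. "The series", "measured", "known", "first", "only" and "open" are said of these compounds alone.

In an assay on membranes from brain for binding affinity to Fatty-acid amide hydrolase 1 (Mus musculus), read by fluorescence, with stated times of 1 h and 30 min (a higher number here means a weaker inhibitor, a lower number a stronger inhibitor), compound 1 `Cc1cnn(C(=O)NCc2ccc(OCc3ccccc3)cc2)c1` gives 1200 nM. Compound 2 `Cc1cnn(C(=O)N2CCN(C(c3ccc4ccccc4c3)c3ccc4ccccc4c3)CC2)c1` shares the methylpyrazole of compound 1 but carries a piperazine bearing two naphthyl groups in place of the benzyloxybenzyl amide; in this assay compound 2 reaches only the limit > 100000 nM. Compound 3 `O=C(N1CCN(C(c2ccc3ccccc3c2)c2ccc3ccccc3c2)CC1)n1cccn1` keeps that core and loses the methyl; in this assay compound 3 likewise reaches only the limit > 100000 nM. The step that the two limits leave unreadable from compound 2 to compound 3 therefore cannot be read, because both values sit at the limit of > 100000 nM in this assay, at which 2 of the 3 values shown sit. Compound 3 thus stands at the edge of what this assay can report, with no number of its own.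

Compound 4 `N#Cc1cnn(C(=O)N2CCN(C(c3ccc4ccccc4c3)c3ccc4ccccc4c3)CC2)c1` differs from compound 3 by cyano in place of hydrogen on an aromatic carbon. Among the measured compounds shown here, no measured step shows what a cyano group does at this position, and the one step that touches this ring, a step that the two limits leave unreadable from compound 2 to compound 3, gives no readable size. For the measured compounds named here, the only guide is that compound 3 stands at the limit and that the change is small. Compound 4 is therefore expected to remain near the limit, with the step of a number no higher from compound 3 to compound 4 (the limit leaves the size open) estimated as none beyond the scatter. For compound 4 the estimate in this assay is 100000 nM, between 20000 nM and 300000 nM.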

Compound 4, half-maximal inhibitory concentration: > 100000 nM
Compound 4: no number, only a limit; the forecaster's own chance of this, stated with the estimate: 70%; the middle value sits exactly at the limit.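

Compound 4, like compound 2 and compound 3, gives only a limit and no number in this assay, so no step among these three compounds can be read. The compounds shown leave open how strongly each of the three inhibits, and whether hydrogen, methyl or cyano at this ring carbon makes any difference.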